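The source may report more compounds than this note shows. Statements on the series, on what has been measured and on what is new or still open speak of the compounds shown alone.

The shared core carries an amide-linked bicyclic portion at one end and a benzylic urea at the other, and the three measured compounds vary only around that urea. Compound 1 `O=C(NCc1ccc(C(=O)N2CCCCc3ccccc32)c(Cl)c1)Nc1c(F)cccc1F` gives 40 nM in a functional assay on HEK293 cells for agonist activity at Vasopressin V2 receptor (Homo sapiens), read by a luciferase reporter and cAMP accumulation; on this read-out lower numbers stand for an effect already at smaller amounts and higher numbers for an effect only at larger amounts of compound. Compound 2 `CCc1cc(C(=O)N2CCCCc3ccccc32)ccc1CNC(=O)Nc1c(F)cccc1F` gives 10 nM in this assay. Compound 3 `Cc1cc(C(=O)N2CCCCc3ccccc32)ccc1CNC(=O)Nc1ccccc1F` gives 30 nM in this assay. Among the three numbers, compound 3 stands second highest: compound 1 is its nearest neighbour, the two lying within the scatter of each other, whereas compound 2 is furthest, with a number lower by a margin beyond the scatter.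

Compound 4 `COC(=O)CNC(=O)NCc1ccc(C(=O)N2CCCCc3ccccc32)cc1C` has not yet been measured in this assay. It differs from compound 3 in one place: (methoxycarbonyl)methyl in place of 2-fluorophenyl on an amide-type nitrogen. The aromatic ring at that end of the urea is thus given up for an open chain ending in an ester.

Going by the values given here, no measured pair in the set shows what such a change does, so the expectation rests on the structural change alone. All three measured compounds carry an aromatic ring on that urea nitrogen, and nothing in the data speaks to a compound without one. The author expects compound 4 to give a higher number in this assay, an expected step of a 10-fold higher number from compound 3 to compound 4 (1.00 log units; beyond the scatter). Compound 4 is estimated at 300 nM, with a range from 60 nM to 1500 nM.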

Compound 4, half-maximal effective concentration: 37 nM
Compound 4: middle estimate off by 8.1-fold (0.91 log units), on the high side; the whole stated range lies above it.
By their numbers in this assay, from the lowest: compound 2; then compounds 3, 4 and 1 (each within the scatter of the next).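

In this assay the exchange gives a 1.2-fold higher number from compound 3 to compound 4 (0.09 log units; within the scatter) and stays within the scatter, so on this amide-type nitrogen the compounds shown reveal no readable difference between the 2-fluorophenyl ring and the open (methoxycarbonyl)methyl chain. Every earlier compound carried an aromatic ring at this end of the urea, and compound 4 now shows that, at least on the core of compound 3, a number of this size does not depend on having one there, even though the entering group has no ring and brings two hydrogen-bond acceptors where the leaving group had none. The data shown offer no measurement that would explain why the two groups read alike.

On these data alone, it remains open whether the ester matters at all, or whether a carboxylic acid, an amine or a longer chain ending in the same ester would serve equally well on this nitrogen. As far as these compounds go, it also remains open whether the same exchange would hold on compound 2, which gives 10 nM with its own aromatic ring in place.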